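Shortening the Hydroxyalkyl Chain on a Shared Core

The source may report more compounds than this note shows. Statements on the series, on what has been measured and on what is new or still open speak of the compounds shown alone.

Compound 1, `CCCS(=O)(=O)Nc1ccc(F)c(-c2cc3cnc(NCC4CC4)nc3n(C)c2=O)c1F`, and compound 2, `CCCS(=O)(=O)Nc1ccc(F)c(-c2cc3cnc(NCCCO)nc3n(C)c2=O)c1F`, were both tested in an ADME assay on Caco-2 cells (Homo sapiens) for permeability; a lower number here means that the compound crosses the layer more slowly, a higher number that the compound crosses the layer faster. In this assay compound 1 gives > 8 10^-6 cm/s, which is a limit of the assay rather than a number. In this assay compound 2 likewise gives > 8 10^-6 cm/s, again a limit rather than a number. The step that the two limits leave unreadable from compound 1 to compound 2 therefore cannot be read, since (the limit of > 8 10^-6 cm/s in this assay, at which 2 of the 2 values shown sit). Compound 2 thus stands at that limit, with no number of its own to place it more closely within the range this assay covers. Compound 3, `CCCS(=O)(=O)Nc1ccc(F)c(-c2cc3cnc(NCCO)nc3n(C)c2=O)c1F`, differs from compound 2 in one place: hydroxy in place of hydroxymethyl on a saturated chain carbon, two bonds along the chain from a nitrogen on an aromatic ring. No measured step covers this change; the only step shown, from compound 1 to compound 2, is itself hidden by the two limits. On the numbers shown there is no basis for expecting a step beyond the scatter in either direction, so for compound 3 the expected step is a step that the limit leaves unreadable from compound 2 to compound 3. Compound 3 is therefore estimated at 12 10^-6 cm/s, between 6 10^-6 cm/s and 25 10^-6 cm/s, and is most likely again reported only as a limit.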

Compound 3, apparent permeability: > 8 10^-6 cm/s
Compound 3: only a limit was reported (the forecaster's own chance of this, stated with the estimate: 80%); the middle value lies beyond the limit too.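

In this assay compound 3 gives > 8 10^-6 cm/s, which is again a limit and not a number. The steps among compound 1, compound 2 and compound 3 therefore cannot be read: the limit of > 8 10^-6 cm/s in this assay, at which 3 of the 3 values shown sit. The compounds shown leave open how far apart these three lie, and whether going from 3-hydroxypropyl to 2-hydroxyethyl changes the read-out at all.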